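The compounds below may be only part of what the source reports. "The series", "measured", "known", "first", "only" and "open" are said of these compounds alone.

Measured so far:
- compound 1, `O=C(/C=C\Nc1ccc(O)cc1)c1cn(-c2ccccc2)nc1-c1ccccc1`: 44600 nM
- compound 2, `O=C(/C=C\Nc1ccc(Cl)cc1)c1cn(-c2ccccc2)nc1-c1ccc(F)cc1`: 21300 nM

In an ADME assay on HaCaT cells (Homo sapiens) for antiproliferative activity, read by MTT assay, with a stated time of 48 h (on this read-out higher numbers stand for weaker inhibition and lower numbers for stronger inhibition), compound 2 holds the lower of the two numbers; compound 1 gives the higher one, and the gap between them lies beyond the usual scatter. The two compounds differ in more than one place, so no single step can be read from them.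

Compound 3, `O=C(/C=C\Nc1ccc(O)cc1)c1cn(-c2ccccc2)nc1-c1ccc(F)cc1`, is not yet measured. It arises from compound 2 by hydroxy in place of chloro on an aromatic carbon, which brings the aniline part of compound 2 to that of compound 1 while the fluorophenyl stays. A move toward the number of compound 1 is expected, i.e. a weakening step from compound 2 to compound 3 in this assay of modest size, a 1.6-fold higher number from compound 2 to compound 3 (0.22 log units; within the scatter). Compound 3 is estimated at 35000 nM, within 15000 nM to 80000 nM.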

Compound 3, half-maximal inhibitory concentration: 16300 nM
The estimate for compound 3 lay 2.1-fold (0.33 log units) above the measured number; the measured number falls inside the stated range.
By their numbers in this assay, from the lowest: compounds 3 and 2 (each within the scatter of the next); then compound 1.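

In this assay, hydroxy in place of chloro on the aromatic carbon gives a 1.3-fold lower number from compound 2 to compound 3 (0.12 log units; within the scatter) and so does not separate the two groups at this position while the fluorophenyl stays. Fluoro in place of hydrogen on an aromatic carbon, with the 4-hydroxyphenyl held, gives a 2.7-fold lower number from compound 1 to compound 3 (0.44 log units; beyond the scatter) and is the first single change in the series that lies beyond the scatter. No measured evidence bears on either step.

As far as these compounds go, whether an amine or a carboxylic acid at the chloro and hydroxy position would also stay within the scatter remains open. Also open, from the compounds shown here alone, is whether the fluoro step holds with 4-chlorophenyl in place of 4-hydroxyphenyl.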